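This account rests on a few compounds, and the source may have more. Where it says the series, first, only, none or still open, it means among the compounds named here.

The study concerns compound 1 `CCCCCCCCO[C@@H]1O[C@@H](C)[C@H](OC(=O)CCCCC)[C@@H](O[C@@H]2O[C@@H](C)[C@H](OC(C)=O)[C@@H](O[C@@H]3O[C@@H](C)[C@H](O)[C@@H](O)[C@H]3OC(C)=O)[C@H]2OC(C)=O)[C@H]1O`, which in a functional assay on NCI-H460 cells (Homo sapiens) for antiproliferative activity, read by MTT assay, with a stated time of 48 h (on this read-out lower numbers stand for stronger inhibition and higher numbers for weaker inhibition), gives 24000 nM. Compound 2 `CCCCCCCCO[C@@H]1O[C@@H](C)[C@H](OC(=O)CCCCC)[C@@H](O[C@@H]2O[C@@H](C)[C@H](OC(C)=O)[C@@H](O)[C@H]2OC(C)=O)[C@H]1O` is its shorter relative; in this assay compound 2 reaches only a limit of the assay, > 500000 nM, and the limit of > 500000 nM in this assay, at which 1 of the 2 values shown sits, shows where it stands among the values recorded. Compound 3 `CCCCCCCCO[C@@H]1O[C@@H](C)[C@H](OC(=O)CCCCC)[C@@H](O[C@@H]2O[C@@H](C)[C@H](OC(C)=O)[C@@H](OC(=O)C(C)(C)C)[C@H]2OC(C)=O)[C@H]1O` is not yet measured and differs from compound 2 by (tert-butyl)carbonyl in place of hydrogen on an oxygen on a saturated carbon. Among the compounds with values here, no measured pair shows what this change does, so the expected step of an at least 3.3-fold lower number from compound 2 to compound 3 (0.52 log units; beyond the scatter) is tentative, leaning toward stronger inhibition. Compound 3 is therefore expected to give 150000 nM, within 30000 nM to 500000 nM.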

Compound 3, half-maximal inhibitory concentration: 141000 nM
Compound 3: the middle estimate sits 1.1-fold (0.03 log units) above what was measured; measured number inside the range.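

In this assay, putting (tert-butyl)carbonyl in place of hydrogen on an oxygen on a saturated carbon gives an at least 3.5-fold lower number from compound 2 to compound 3 (0.54 log units; beyond the scatter), which shows that this position responds to substitution. The true size of this step stays unknown, since the value for compound 2 is a limit of the assay and not a number: the limit of > 500000 nM in this assay, at which 1 of the 3 values shown sits.

Going by these compounds, whether a smaller acetyl group, a longer straight acyl chain or an amine-bearing acyl group at this oxygen would give a similar step remains open. On these data alone, it also remains open whether the tert-butyl part matters or the carbonyl alone suffices.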